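Removing the Ring Methyl from Compound 1

The compounds below may be only part of what the source reports. "The series", "measured", "known", "first", "only" and "open" are said of these compounds alone.

In a functional assay on CHO cells (Cricetulus griseus) for inhibition (on this read-out lower numbers stand for stronger inhibition and higher numbers for weaker inhibition), compound 1 `Cc1cc(-c2c(O)nc3cc(Cl)c(C(=O)Nc4ccncn4)cc3c2OCC[C@@H]2CCC[C@H](C)N2)cc(C)c1C` gives 9.8 nM. This sits within the scatter of both compound 2 `Cc1cc(C)cc(-c2c(O)nc3cc(Cl)c(C(=O)Nc4ccncn4)cc3c2OCC[C@@H]2CCC[C@H](C)N2)c1` at 8.7 nM and compound 3 `Cc1cc(C)cc(-c2c(O)nc3cc(Cl)c(C(=O)Nc4ccncn4)cc3c2OCC[C@@H]2CCC[C@@H](C)N2)c1` at 11.5 nM, so the three values form a single group.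

Compound 4 `Cc1cc(-c2c(O)nc3cc(Cl)c(C(=O)Nc4ccncn4)cc3c2OCC[C@@H]2CCCCN2)cc(C)c1C` differs from compound 1 by hydrogen in place of methyl on a saturated ring carbon. In words, this is hydrogen in place of methyl on a saturated ring carbon, turning 6-methylpiperidin-2-yl into piperidin-2-yl.

Among the measured compounds shown here, two measured steps bear on this change. The step of a 1.1-fold lower number from compound 1 to compound 2 (0.05 log units; within the scatter) also removes a methyl, but from an aromatic carbon, so it is only a loose guide. The step of a 1.3-fold higher number from compound 2 to compound 3 (0.12 log units; within the scatter) involves the same saturated ring carbon and rests on (the fact that compounds 2 and 3 differ only in the configuration as drawn). From the compounds shown here alone, both are small, but neither removes the ring methyl itself, so the direction remains open.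

In this assay, no change beyond the scatter is expected, and the expected step is a 1.2-fold higher number from compound 1 to compound 4 (0.09 log units; within the scatter). For compound 4, the estimated value is 12 nM, with an expected range of 5 nM to 35 nM.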

Compound 4, half-maximal inhibitory concentration: 2.2 nM
Compound 4: middle estimate off by 5.5-fold (0.74 log units), on the high side; the whole stated range lies above it.
By their numbers in this assay, from the lowest: compound 4; then compounds 2, 1 and 3 (each within the scatter of the next).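

In this assay, among the compounds shown here, the methyl on this saturated ring carbon proves to matter in a way the earlier compounds did not reveal: replacing it with hydrogen gives a 4.5-fold lower number from compound 1 to compound 4 (0.65 log units; beyond the scatter). Redrawing the configuration at that carbon had stayed within the scatter, at a 1.3-fold higher number from compound 2 to compound 3 (0.12 log units; within the scatter), so the two forms of 6-methylpiperidin-2-yl gave no hint of what piperidin-2-yl would do, and that comparison rests on one point: the fact that compounds 2 and 3 differ only in the configuration as drawn. The step comes from a single pair, so it describes this change in compound 1 only.

From the compounds shown here alone, whether an ethyl group, a hydroxymethyl group or a fluorine on the same carbon would track the methyl or the hydrogen remains open. So does whether the same step would appear with the aromatic substitution of compound 2.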